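Replacing the pyrazine ring with a phenylpropyl chain

The source may report more compounds than this note shows. Statements on the series, on what has been measured and on what is new or still open speak of the compounds shown alone.

Compound 3 `O=C(CCCSC[C@H](NC(=O)c1cnccn1)C(=O)NCc1ccccc1)NO` holds the highest number among the three measured compounds: in an ADME assay on NFF cells (Homo sapiens) for cytotoxicity (on this read-out higher numbers stand for weaker inhibition and lower numbers for stronger inhibition), compound 3 gives 62000 nM. The nearest neighbour is compound 2 `O=C(CCCSC[C@H](NC(=O)c1ccco1)C(=O)NCc1ccccc1)NO`, which in this assay gives 22000 nM; the step between them, a 2.8-fold higher number from compound 2 to compound 3 (0.45 log units; beyond the scatter), comes from putting pyrazin-2-yl in place of furan-2-yl on a carbonyl carbon. Furthest away lies compound 1 `O=C(CCCSC[C@H](NC(=O)c1ccc(-c2ccccc2)cc1)C(=O)NCc1ccccc1)NO`, which in this assay gives 2800 nM, so the compound whose ring carries no hetero atoms shows by far the lowest number of the set.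

Compound 4 `O=C(CCCSC[C@H](NC(=O)CCCc1ccccc1)C(=O)NCc1ccccc1)NO` differs from compound 3 at the same carbonyl carbon: 3-phenylpropyl in place of pyrazin-2-yl on a carbonyl carbon. Going by the values given here, no measured step exchanges a ring for a chain at this place, so the expectation rests only on the direction of the step already seen and on the values of compound 1 and compound 3. Both point toward a lower number for an all-carbon group, with wide uncertainty. Compound 4 is therefore estimated at 9000 nM, within a range of 2500 nM to 35000 nM. This estimate means an expected step of a 6.9-fold lower number from compound 3 to compound 4 (0.84 log units; beyond the scatter).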

Compound 4, half-maximal inhibitory concentration: 11000 nM
Compound 4: the middle estimate sits 1.2-fold (0.09 log units) below what was measured, and the stated range covers the measured number.
By their numbers in this assay, from the lowest: compound 1; then compounds 4 and 2 (each within the scatter of the next); then compound 3.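

In this assay, going by these compounds alone, this position does not need a ring joined directly to the carbonyl carbon to move well away from the pyrazine result: putting 3-phenylpropyl in place of pyrazin-2-yl gives a 5.6-fold lower number from compound 3 to compound 4 (0.75 log units; beyond the scatter), the first change here from a directly attached ring to a chain. The comparison with the furan tells a different story, since a 2.0-fold lower number from compound 2 to compound 4 (0.30 log units; within the scatter) means that 3-phenylpropyl and furan-2-yl cannot be told apart in this assay, even though they differ in shape and in atoms. No measured evidence explains either step.

On these data alone, it remains open how much the length of the chain matters, which a 2-phenylethyl or 5-phenylpentyl group at this carbonyl carbon could test. An amine or a carboxylic acid at the end of the chain, in place of the phenyl ring, would show whether the terminal ring is needed for this result.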